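Aryl swaps on the ring amine nitrogen: compound 3

This account rests on a few compounds, and the source may have more. Where it says the series, first, only, none or still open, it means among the compounds named here.

Compound 1 `N#Cc1ccc(Nc2nc(Oc3ccnc4ccccc34)nc(N3CCN(c4ccc(F)cc4)CC3)n2)cc1C(F)(F)F`: in a functional assay on DU-145 cells (Homo sapiens) for cytotoxicity, read by sulforhodamine B assay, with a stated time of 48 h (a higher number here means a weaker inhibitor of growth, a lower number a stronger inhibitor of growth), compound 1 gives > 100000 nM, which is a limit of the assay.
Compound 2 `N#Cc1ccc(Nc2nc(Oc3ccnc4ccccc34)nc(N3CCN(c4ccccn4)CC3)n2)cc1C(F)(F)F`: in this assay compound 2 gives 85900 nM.

Going by the values given here, compound 2 carries the only numeric value in this assay. The other entry is a limit, compound 1 sitting at the limit of > 100000 nM in this assay, at which 1 of the 2 values shown sits. Compound 3 `COc1ccc(N2CCN(c3nc(Nc4ccc(C#N)c(C(F)(F)F)c4)nc(Oc4ccnc5ccccc45)n3)CC2)cc1` differs from compound 2 by 4-methoxyphenyl in place of pyridin-2-yl on an amine nitrogen in a ring. Among the compounds with values here, the single measured step at this position, an at least 1.1-fold lower number from compound 1 to compound 2 (0.06 log units; that floor lies within the scatter), lies within the scatter, so no shift beyond the scatter is expected; the step expected is a 1.0-fold higher number from compound 2 to compound 3 (0.02 log units; within the scatter). Compound 3 is therefore estimated at 90000 nM, in the range 40000 nM to 200000 nM, with a real chance that only a limit is reported.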

Compound 3, concentration for 50% growth inhibition: > 100000 nM
Compound 3 gave a limit, no number; the forecaster's own chance of this, stated with the estimate: 45%; at least 1.1-fold (0.04 log units) between middle value and limit.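

Replacing pyridin-2-yl with 4-methoxyphenyl gives an at least 1.1-fold higher number from compound 2 to compound 3 (0.06 log units; that floor lies within the scatter) in this assay, so no shift beyond the scatter can be claimed for this change. The methoxy for fluoro step between the two limits cannot be read. Two carbon-only aromatic rings at this position, in compound 1 and compound 3, now end at the same limit: the limit of > 100000 nM in this assay, at which 2 of the 3 values shown sit.

Going by these compounds, how far compound 1 and compound 3 lie past that limit stays open. Also open, on these data alone, is whether a methyl or acetyl group on this ring nitrogen, in place of an aromatic ring, would lower the number beyond the scatter.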